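Ethoxycarbonyl in place of the methoxy(methyl)carbamoyl group

The compounds below may be only part of what the source reports. "The series", "measured", "known", "first", "only" and "open" are said of these compounds alone.

Measured so far:
compound 1, `CCOC(=O)C[C@H]1[C@@H](O[Si](C)(C)C(C)(C)C)[C@H](n2cnc3c(NC(=O)Nc4ccccc4)ncnc32)O[C@@H]1COC(=O)NC`: 2.33 nM
compound 2, `CNC(=O)NC[C@H]1O[C@@H](n2cnc3c(NC(=O)Nc4ccccc4)ncnc32)[C@H](O[Si](C)(C)C(C)(C)C)[C@@H]1CC(=O)N(C)OC`: 4.2 nM

In a functional assay on HCT-116 cells (Homo sapiens) for antiproliferative activity (on this read-out lower numbers stand for stronger inhibition of growth and higher numbers for weaker inhibition of growth), compound 1 gives 2.33 nM and compound 2 gives 4.2 nM. Of the two numbers shown, compound 2 stands at the upper one, but compound 1 sits within the usual scatter of it, so the two values show no difference that can be read as real. For the measured compounds named here, no single-point step between measured compounds is available in this set.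

Compound 3, `CCOC(=O)C[C@H]1[C@@H](O[Si](C)(C)C(C)(C)C)[C@H](n2cnc3c(NC(=O)Nc4ccccc4)ncnc32)O[C@@H]1CNC(=O)NC`, differs from compound 2 in one place: ethoxy in place of methoxy(methyl)amino on a carbonyl carbon. The group that enters, ethoxycarbonyl, is the same group that compound 1 carries at this position, and compound 1 in this assay gives 2.33 nM, a number within the scatter of compound 2. On that basis the step from compound 2 to compound 3 is expected to be small, with no clear direction, and is estimated as a 1.3-fold lower number from compound 2 to compound 3 (0.12 log units; within the scatter), within the scatter. Compound 3 is therefore expected to give about 3.2 nM in this assay, with a range from 1.2 nM to 8.5 nM.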

Compound 3, concentration for 50% growth inhibition: 3.2 nM
Beside the measured number, compound 3's estimate shows no gap at the digits printed; low and high end bracket the measured number.
By their numbers in this assay, from the lowest: compounds 1, 3 and 2 (each within the scatter of the next).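

In this assay, for the compounds shown here, ethoxy in place of methoxy(methyl)amino on a carbonyl carbon gives a 1.3-fold lower number from compound 2 to compound 3 (0.12 log units; within the scatter), the first reading of this place alone, with (methylcarbamoyl)amino held constant. The second single-place reading, (methylcarbamoyl)amino in place of (methylcarbamoyl)oxy on a saturated chain carbon bound to a saturated ring carbon, gives a 1.4-fold higher number from compound 1 to compound 3 (0.14 log units; within the scatter), with ethoxycarbonyl held constant, so compound 1 and compound 2, which differ in two places, are now joined through compound 3 by steps that each lie within the scatter. Nothing available explains why either exchange leaves the read-out within the scatter.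

As far as these compounds go, both exchanges stay within the scatter, so the three compounds do not show which groups at either place would move the number, and it remains open whether a carboxylic acid or a dimethylamino group on the same carbonyl carbon would stay within the scatter of compound 3. From the compounds shown here alone, a free amine in place of (methylcarbamoyl)amino on the saturated chain carbon is equally open, since every group compared there so far carries the methylcarbamoyl unit.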